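Acetyl replaces methoxy on the aryl ring of compound 3

This account rests on a few compounds, and the source may have more. Where it says the series, first, only, none or still open, it means among the compounds named here.

Compound 3 `CCN(CC)c1cc(C)nc(N(CC)c2c(Br)cc(OC)cc2OC)n1` gives 48 nM in an assay on isolated protein for binding affinity to corticotropin-releasing factor receptor 1 (Homo sapiens); a lower number here means a stronger inhibitor, a higher number a weaker inhibitor. Among the three compounds with numbers, compound 3 stands highest. Compound 1 `CCN(c1nc(C)cc(C)n1)c1c(Br)cc(OC)cc1OC` gives 12 nM in this assay, and the step of a 4.0-fold higher number from compound 1 to compound 3 (0.60 log units; beyond the scatter) is a diethylamino in place of methyl on an aromatic carbon. Compound 2 `CCN(CC)c1cc(C)nc(N(CC)c2c(Cl)cc(OC)cc2OC)n1` gives 10 nM in this assay, and the step of a 4.8-fold higher number from compound 2 to compound 3 (0.68 log units; beyond the scatter) is a bromo in place of chloro on an aromatic carbon. Both steps go beyond the scatter, and both raise the number toward compound 3.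

Compound 4 `CCN(CC)c1cc(C)nc(N(CC)c2c(Br)cc(C(C)=O)cc2OC)n1` has not yet been measured. Its difference from compound 3 is acetyl in place of methoxy on an aromatic carbon. Neither of the two measured steps touches this group: one changes a substituent on the other ring, the other swaps one halogen for another. So nothing measured bears directly on the change, and its size cannot be read from what is known. With no guide, the expectation for compound 4 is a step of a 1.3-fold higher number from compound 3 to compound 4 (0.10 log units; within the scatter), which is to say no change beyond the scatter, held with a wide range. The estimate for compound 4 in this assay is 60 nM, expected to lie between 15 nM and 250 nM.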

Compound 4, inhibition constant: 28 nM
For compound 4 the middle estimate is 2.1-fold (0.33 log units) above the measured one; low and high end bracket the measured number.
By their numbers in this assay, from the lowest: compounds 2 and 1 (each within the scatter of the next); then compounds 4 and 3 (each within the scatter of the next).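

The place para to a large group, which neither earlier step touched, now has a measured change: in this assay, a 1.7-fold lower number from compound 3 to compound 4 (0.23 log units; within the scatter), so acetyl and methoxy cannot be told apart there. Unlike the diethylamino and bromo steps, both beyond the scatter, this exchange of a methoxy group for an acetyl group, which brings a double bond outside the aromatic ring and leaves the count of hydrogen-bond acceptors unchanged, leaves the binding number of the series where it was, so this place accepts at least this one replacement on the core of compound 3. No measurement of any other property is available to account for this outcome, so the result describes only what the binding number does.

Going by these compounds, whether this place would accept groups of a different kind, such as an amine, a carboxylic acid or a longer acyl chain, stays open, since a single replacement says little about the range allowed there. On these data alone, it is equally open whether acetyl would behave the same way alongside chloro in place of bromo, as in compound 2, or with methyl in place of diethylamino, as in compound 1.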